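Cytotoxicity notes: thienopyrimidine ether amides, N-aryl variation

A few compounds are considered here, and "the series" means these few. Any claim that something is new, unique, unknown or untested is made for them only; others in the source may bear on it.

Measured so far:
- compound 1, `CNC(=O)c1cc(Oc2ccc(NC(=O)c3nn(-c4ccccc4F)c(=O)cc3C)cc2F)ccn1`: > 40000 nM in a functional assay on HepG2 cells (Homo sapiens) for cytotoxicity, read by MTT assay, with a stated time of 72 h; a higher number here means a weaker inhibitor, a lower number a stronger inhibitor
- compound 2, `Cc1cc(=O)n(-c2ccccc2C(F)(F)F)nc1C(=O)Nc1ccc(Oc2ncnc3ccsc23)cc1`: 9230 nM in this assay
- compound 3, `Cc1cc(=O)n(-c2ccccc2C(F)(F)F)nc1C(=O)Nc1ccc(Oc2ncnc3sccc23)cc1`: > 40000 nM in this assay

Compound 1 reaches only the limit of this assay. Compound 3 likewise sits at the limit of this assay and carries no number of its own; it is one of two values in the series at that limit (the limit of > 40000 nM in this assay, at which 2 of the 3 values shown sit). For the measured compounds named here, the only step with a number attached, an at least 4.3-fold higher number from compound 2 to compound 3 (0.63 log units; beyond the scatter), concerns the exchange of one fused bicyclic ether for its isomer and says nothing about the aryl on the ring nitrogen.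

Compound 4, `Cc1cc(=O)n(-c2cccc(F)c2)nc1C(=O)Nc1ccc(Oc2ncnc3sccc23)cc1`, differs from compound 3 by 3-fluorophenyl in place of 2-(trifluoromethyl)phenyl on an aromatic nitrogen. Going by the values given here, no measured pair changes this aryl alone, so no step can be carried over. Compound 1 bears a fluorophenyl on the same nitrogen but differs in the ether part as well, and its value is only a limit, so it offers a loose hint at best that a small halogenated aryl here is compatible with weak activity.

Given compound 3 at the limit of this assay and no step bearing on the change, compound 4 is expected to remain weak, with an estimated step of a number no higher from compound 3 to compound 4 (the limit leaves the size open) and an expected value of 40000 nM (range 15000 nM to 100000 nM), most likely again reported only as a limit.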

Compound 4, half-maximal inhibitory concentration: 18500 nM
Beside the measured number, compound 4's estimate is 2.2-fold (0.33 log units) above it, within the range that was stated.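

In this assay, the aryl on the ring nitrogen now has a step of its own: an at least 2.1-fold lower number from compound 3 to compound 4 (0.33 log units; beyond the scatter), with 3-fluorophenyl in place of 2-(trifluoromethyl)phenyl. For the compounds shown here, this shows that the read-out at this position depends on the aryl it carries, which the earlier compounds could not show, and that a number can be reached here on the core of compound 3. Compound 3 itself has only a limit, so the step gives a minimum and its full size stays unknown: the limit of > 40000 nM in this assay, at which 2 of the 4 values shown sit.

The exchange alters both the substituent and where it stands on the phenyl ring, so the shown pair cannot separate the effect of fluorine versus trifluoromethyl from the effect of their placement. Going by these compounds, it also remains open whether an unsubstituted phenyl, a 2-fluorophenyl or a phenyl bearing an amine or a carboxylic acid would give a lower or higher number here, and whether 3-fluorophenyl would produce a similar step on the isomeric ether of compound 2.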